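Exchanging One Ring Group on Compound 1

The source may report more compounds than this note shows. Statements on the series, on what has been measured and on what is new or still open speak of the compounds shown alone.

In a functional assay on PLC-PRF-5 cells (Homo sapiens) for inhibition, read by MTT assay, with a stated time of 72 h (a lower number here means a stronger inhibitor, a higher number a weaker inhibitor), compound 1 `Nc1ncnc2c1c(-c1cnc3[nH]ccc3c1)nn2CCCCCCCCC(=O)NO` gives 14900 nM, the strongest of the three measured compounds. Compound 2 `Nc1ncnc2c1c(-c1cnc3[nH]ccc3c1)nn2CCCCCC(=O)NO` gives only a limit of the assay, > 150000 nM. Compound 3 `Nc1ncnc2c1c(-c1cnc3[nH]ccc3c1)nn2CCCCCCC(=O)NO` also gives a limit, > 50000 nM. Shortening the chain mattered: an at least 10-fold higher number from compound 1 to compound 2 (1.00 log units; beyond the scatter) and an at least 3.3-fold higher number from compound 1 to compound 3 (0.52 log units; beyond the scatter).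

Compound 4 `Nc1nc2cc(-c3nn(CCCCCCCCC(=O)NO)c4ncnc(N)c34)ccc2o1` keeps the chain of compound 1 but exchanges a ring group: a group of 10 heavy atoms (7 carbon, 2 nitrogen, 1 oxygen; one five-membered aromatic ring with 2 hetero atoms, one six-membered aromatic ring of carbon only) in place of a group of 9 heavy atoms (7 carbon, 2 nitrogen; one five-membered aromatic ring with 1 hetero atom, one six-membered aromatic ring with 1 hetero atom), on an aromatic carbon. The measured steps changed only the chain, so they give no size or direction for this exchange. The expectation therefore stays close to compound 1 at 14900 nM, with no step beyond the scatter in this assay. The estimated outcome is a 1.2-fold lower number from compound 1 to compound 4 (0.09 log units; within the scatter). For compound 4, the estimated value is 12000 nM, with an expected range from 2500 nM to 50000 nM.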

Compound 4, half-maximal inhibitory concentration: 24000 nM
Estimate against measurement, compound 4: 2.0-fold (0.30 log units) below; the measured number falls inside the stated range.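

Placing 2-amino-1,3-benzoxazol-5-yl on this aromatic carbon gives, in this assay, a 1.6-fold higher number from compound 1 to compound 4 (0.21 log units; within the scatter). Compound 1 and compound 4 therefore cannot be told apart here, even though the entering group has a six-membered aromatic ring of carbon only and more hydrogen-bond acceptors, a kind of exchange the chain steps never tested. No measurement shown explains why these two ring groups read alike.

Going by these compounds, whether a plain phenyl ring or a carboxylic acid on this carbon would read the same stays open. So does how 2-amino-1,3-benzoxazol-5-yl behaves with a shorter or longer chain.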